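Moving the ring nitrogen within a pyridine on the amide

The compounds below may be only part of what the source reports. "The series", "measured", "known", "first", "only" and "open" are said of these compounds alone.

Measured so far in a functional assay on the whole organism (strain Wistar) for inhibition, with Rattus norvegicus as the target, read by paw edema, with a stated time of 4 h, at a dose of 100 mg/kg; a higher number here means more inhibition at the dose given (going by the name of the read-out), a lower number less inhibition:
- compound 1 `COc1cc2c(cc1OC)C(CC(=O)Nc1ccccc1)CC2` gives 37.5%
- compound 2 `COc1cc2c(cc1OC)C(CC(=O)Nc1ccccn1)CC2` gives 29.7%

The two compounds share one core and differ only in the aromatic ring on the amide-type nitrogen. The step of a number 7.8 percentage points lower from compound 1 to compound 2 (within the scatter) is within the scatter, so the two numbers cannot be placed in order. Within the data shown here, compound 2 therefore stands level with compound 1, the only other number available.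

Compound 3 `COc1cc2c(cc1OC)C(CC(=O)Nc1cccnc1)CC2` differs from compound 2 by pyridin-3-yl in place of pyridin-2-yl on an amide-type nitrogen. Among the measured compounds shown here, only one measured step touches this place, the exchange of phenyl for pyridin-2-yl, and it stayed within the scatter. For the measured compounds named here, no measured step moves the nitrogen within the pyridine itself. Starting from compound 2, the change is expected to give a step of about a number 2.3 percentage points higher from compound 2 to compound 3 (within the scatter), not beyond the scatter. Compound 3 is estimated at 32%, with a range from 20% to 44%.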

Compound 3, a percentage reported as inhibition, in the whole organism at one dose (the size of the read-out at that dose, not a potency): 34.4%
Compound 3: middle estimate off by 2.4 percentage points, on the low side, and the stated range covers the measured number.
By their numbers in this assay, from the lowest: compounds 2, 3 and 1 (each within the scatter of the next).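

Compound 2 and compound 3 share the same atoms, so this pair tests the place of the ring nitrogen directly. Exchanging pyridin-2-yl for pyridin-3-yl on the amide-type nitrogen in this assay gives a small difference (a number 4.7 percentage points higher from compound 2 to compound 3 (within the scatter)), and these two placements of the nitrogen cannot be told apart. Pyridin-3-yl in place of phenyl also stays within the scatter (a number 3.1 percentage points lower from compound 1 to compound 3 (within the scatter)), so all three rings stand level at this dose, and no measurement here offers an explanation for these results.

From the compounds shown here alone, whether pyridin-4-yl would stand level with these three rings remains open. So does the outcome of placing an amine or a carboxylic acid on the ring, or of putting a longer chain between the ring and the amide-type nitrogen.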